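The compounds below may be only part of what the source reports. "The series", "measured", "known", "first", "only" and "open" are said of these compounds alone.

Measured so far in an ADME assay on cells (Homo sapiens) for cytotoxicity, read by polymerase chain reaction, with a stated time of 3 days; a higher number here means that more compound is tolerated, a lower number that less compound is tolerated:
- compound 1, `Nc1nc(Cl)c(-c2nc3ccc(F)cc3s2)c(N[C@@H]2C[C@H](CO)[C@@H](O)[C@H]2O)n1`: > 25000 nM
- compound 2, `Nc1nc(Cl)c(-c2nc3ccc(Cl)cc3s2)c(N[C@@H]2C[C@H](CO)[C@@H](O)[C@H]2O)n1`: 16000 nM
- compound 3, `Cc1nc(NC(C)C)nc(N[C@@H]2C[C@H](CO)[C@@H](O)[C@H]2O)c1-c1nc2ccccc2s1`: 13000 nM

The value of compound 1 is a limit of this assay, not a number; it sits at the limit of > 25000 nM in this assay, at which 1 of the 3 values shown sits. Of the two numbers, compound 3 has the lowest, and its nearest neighbour is compound 2, whose number is higher by a margin within the scatter, so the two cannot be told apart. Among the measured compounds shown here, the only step recorded between measured compounds is an at least 1.5-fold lower number from compound 1 to compound 2 (0.19 log units; that floor lies within the scatter), and its floor lies within the scatter.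

Compound 4, `CCOC(=O)NCCNc1nc(C)c(-c2nc3ccccc3s2)c(N[C@@H]2C[C@H](CO)[C@@H](O)[C@H]2O)n1`, is not yet measured. It differs from compound 3 by 2-((ethoxycarbonyl)amino)ethyl in place of isopropyl on a nitrogen on an aromatic ring. For the measured compounds named here, this change lies on a nitrogen on an aromatic ring, whereas the one recorded step concerns a halogen on an aromatic carbon, so no measured step bears on it. With no guidance in the shown data, a step in this assay beyond the scatter is not expected in either direction, which means compound 4 is estimated to stay close to compound 3, with a 1.1-fold higher number from compound 3 to compound 4 (0.03 log units; within the scatter). Compound 4 is therefore expected to give about 14000 nM in this assay, within a range of 5000 nM to 40000 nM.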

Compound 4, half-maximal cytotoxic concentration: 12000 nM
For compound 4 the middle estimate is 1.2-fold (0.07 log units) above the measured one, and the stated range covers the measured number.
By their numbers in this assay, from the lowest: compounds 4, 3 and 2 (each within the scatter of the next). At a limit, above all of these: compound 1.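

In this assay, the nitrogen on an aromatic ring accepts a much larger substituent without a step beyond the scatter, with a 1.1-fold lower number from compound 3 to compound 4 (0.03 log units; within the scatter). Isopropyl, with 3 heavy atoms and no hydrogen-bond donor or acceptor, gives way to 2-((ethoxycarbonyl)amino)ethyl, with 8 heavy atoms, a carbonyl, 1 hydrogen-bond donor and 2 hydrogen-bond acceptors, so both size and atom content change at once while the number stays within the scatter; the earlier step concerned only a halogen on an aromatic carbon and said nothing about this nitrogen. Nothing in the data shown accounts for why this exchange leaves the number within the scatter.

As far as these compounds go, whether the same holds for other chains on this nitrogen stays open, for example a chain ending in a primary amine or a carboxylic acid, or a longer chain carrying the same carbamate. From the compounds shown here alone, it also stays open whether a substituent of this kind would behave alike on the core of compound 2, which carries a different set of groups.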